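Series notes: flavone scaffold, Huh-7 cytotoxicity

The compounds below may be only part of what the source reports. "The series", "measured", "known", "first", "only" and "open" are said of these compounds alone.

Measured compounds:
Compound 1 `CN1CCN(c2ccc(-c3cc(=O)c4c(O)c(O)c(O)cc4o3)cc2)CC1` — in a toxicity assay on Huh-7 cells (Homo sapiens) for cytotoxicity, read by CCK-8 assay, with a stated time of 24 h (on this read-out higher numbers stand for lower toxicity in this test and lower numbers for higher toxicity in this test), compound 1 gives a limit of > 100000 nM.
Compound 2 `COc1cc2oc(-c3ccc(Nc4ccc(F)cc4)cc3)cc(=O)c2c(OC)c1OC` — in this assay compound 2 gives 77600 nM.
Compound 3 `O=c1cc(-c2ccccc2)oc2c(-c3cc(F)cc(F)c3)c(O)c(O)c(O)c12` — in this assay compound 3 gives a limit of > 100000 nM.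

Compound 3 stands at the limit of > 100000 nM in this assay, at which 2 of the 3 values shown sit. Going by the values given here, the value for compound 2 is the only number among the three, and compound 3 sits at a limit rather than at a number, so the two cannot be ordered beyond the fact that compound 2 falls inside the range while compound 3 does not.

Compound 4 `O=c1cc(-c2ccccc2)oc2c(-c3ccccc3)c(O)c(O)c(O)c12` is not yet measured. It differs from compound 3 as follows: phenyl in place of 3,5-difluorophenyl on an aromatic carbon. The change removes two fluorine atoms from a pendant ring on the shared core and leaves the three hydroxy groups and the rest of the scaffold untouched. Among the compounds with values here, no measured pair in this set differs in a single place, so the step cannot be read off any neighbour. Given that compound 3 sits at > 100000 nM, the step from compound 3 to compound 4 in this assay is expected to be none beyond the scatter, a step that the limit leaves unreadable from compound 3 to compound 4. Compound 4 is therefore estimated at 120000 nM in this assay, with a range from 50000 nM to 300000 nM, and most likely reported as a limit again.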

Compound 4, half-maximal cytotoxic concentration: 86300 nM
Beside the measured number, compound 4's estimate is 1.4-fold (0.14 log units) above it, within the range that was stated.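

Going by these compounds alone, this is the only step that can be read at this position: in this assay, phenyl in place of 3,5-difluorophenyl on an aromatic carbon gives an at least 1.1-fold lower number from compound 3 to compound 4 (0.06 log units; that floor lies within the scatter). Compound 4 gives a number, 86300 nM, so a phenyl at this position with the three hydroxy groups in place still falls inside the measurable range. Compound 3 gives > 100000 nM, which is a limit of the assay and not a number, and the true size of the step stays unknown because of that limit: the limit of > 100000 nM in this assay, at which 2 of the 4 values shown sit.

As far as these compounds go, what a pendant ring carrying a single fluorine, a methoxy group or an amine would give at this position remains open, as does a carboxylic acid in place of the ring. Also open, from the compounds shown here alone, is whether the same change gives a similar step on a core with methoxy groups in place of the hydroxy groups.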